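From compound 1 to compound 4: trifluoromethyl gives way to hydrogen

The source may hold more compounds than are shown below. What is called first, only, known or untested is meant among the compounds shown, and "the series" means these compounds.

In an ADME assay on the whole organism (Rattus norvegicus), at a dose of 2 mg/kg by the oral route (a lower number here means less compound in the circulation, a higher number more compound in the circulation at the dose given), compound 1 `COc1cc(OCc2csc(-c3ccc(C(F)(F)F)cc3)n2)c2cc(-c3cn4nc(OC)sc4n3)oc2c1` gives 726 ng.h/mL. Compound 3 `COc1cc(OCc2cccc(-c3cnc(OC)cn3)c2)c2cc(-c3cn4nc(OC)sc4n3)oc2c1` gives 722 ng.h/mL, within the scatter of compound 1. Compound 2 `COc1cc(OCc2cccc(-c3ccc(OC)nc3)c2)c2cc(-c3cn4nc(OC)sc4n3)oc2c1` gives 1800 ng.h/mL, and its distance from each of the other two numbers is greater than the usual scatter.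

Compound 4 `COc1cc(OCc2csc(-c3ccccc3)n2)c2cc(-c3cn4nc(OC)sc4n3)oc2c1` differs from compound 1 at a single place: hydrogen in place of trifluoromethyl on an aromatic carbon. This is hydrogen in place of trifluoromethyl on an aromatic carbon, so 4-(trifluoromethyl)phenyl becomes phenyl.

Going by the values given here, no measured step makes this change. Among the compounds with values here, the only step available, a 2.5-fold lower number from compound 2 to compound 3 (0.40 log units; beyond the scatter), exchanges 6-methoxypyridin-3-yl for 5-methoxypyrazin-2-yl, which are different groups. It shows that a single change on an aromatic carbon can move the number modestly, but it gives no direction for the removal of trifluoromethyl. No shift beyond the scatter is therefore expected, although a modest one either way remains possible.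

The expected change is a 1.1-fold lower number from compound 1 to compound 4 (0.05 log units; within the scatter). Compound 4 is estimated at 650 ng.h/mL, with an expected range from 300 ng.h/mL to 1500 ng.h/mL.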

Compound 4, area under the concentration-time curve: 3920 ng.h/mL
Estimate against measurement, compound 4: 6.0-fold (0.78 log units) below; measured number above the stated range.
By their numbers in this assay, from the lowest: compounds 3 and 1 (each within the scatter of the next); then compound 2; then compound 4.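

In this assay, the step of a 5.4-fold higher number from compound 1 to compound 4 (0.73 log units; beyond the scatter) shows that the group on this six-membered aromatic ring of carbon only matters: this single change moves the number beyond the scatter. The earlier step, a 2.5-fold lower number from compound 2 to compound 3 (0.40 log units; beyond the scatter), concerned other groups and could not show this, whereas the pair of compound 1 and compound 4 shows that, in this series, phenyl gives more compound in the circulation than 4-(trifluoromethyl)phenyl at the dose given. No measurement offered here accounts for the size of this step.

The compounds shown leave open whether a smaller group at this place, such as a chlorine atom, or an amine would give a number closer to that of compound 1 or that of compound 4. They also leave open whether removing trifluoromethyl would have a similar effect on a different core.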